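Carboxy for Fluoro on the Aryl Ketone

The source may report more compounds than this note shows. Statements on the series, on what has been measured and on what is new or still open speak of the compounds shown alone.

Three compounds that share a core and a ketone-linked double bond have been measured in a functional assay on MDA-MB-231 cells (Homo sapiens) for cytotoxicity, read by MTT assay, with a stated time of 48 h; on this read-out higher numbers stand for weaker inhibition and lower numbers for stronger inhibition. Compound 1 `Cn1cccc1C(=O)/C=C/c1ccc2c(c1)B(O)OC2` reaches only the limit of the assay, giving > 100000 nM. Compound 2 `O=C(/C=C/c1ccc2c(c1)B(O)OC2)c1ccc(F)cc1` gives 1600 nM, the lowest of the two real numbers. Compound 3 `O=C(/C=C/c1ccc2c(c1)B(O)OC2)c1ccccc1O` gives 16900 nM. Swapping the ring on the carbonyl carbon moves the numbers strongly: an at least 62-fold lower number from compound 1 to compound 2 (1.79 log units; beyond the scatter), and an 11-fold higher number from compound 2 to compound 3 (1.02 log units; beyond the scatter).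

Compound 4 `O=C(O)c1ccc(C(=O)/C=C/c2ccc3c(c2)B(O)OC3)cc1` has not yet been measured. It differs from compound 2 at one spot: carboxy in place of fluoro on an aromatic carbon, on an aromatic carbon of a six-membered aromatic ring of carbon only, para to a large group. Among the compounds with values here, no measured step changes exactly this spot. The nearest guide is the step in which the 4-fluorophenyl of compound 2 was replaced by another ring, an 11-fold higher number from compound 2 to compound 3 (1.02 log units; beyond the scatter), which raised the number beyond the scatter. Because an 11-fold higher number from compound 2 to compound 3 (1.02 log units; beyond the scatter) shows that leaving the 4-fluorophenyl of compound 2 costs potency, a rise is expected here too, though the size is uncertain.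

For compound 4 the estimate in this assay is 8000 nM, with a likely range from 2000 nM to 40000 nM, which is an expected step of a 5.0-fold higher number from compound 2 to compound 4 (0.70 log units; beyond the scatter).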

Compound 4, half-maximal inhibitory concentration: > 100000 nM
Compound 4: a limit, no number; the forecaster's own chance of this, stated with the estimate: 10%; middle value at least 12-fold (1.09 log units) away from the limit.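

Exchanging only the fluoro for carboxy, with the ring and the rest of the molecule kept, gives an at least 62-fold higher number from compound 2 to compound 4 (1.79 log units; beyond the scatter) in this assay. The earlier steps shown here each replaced a whole ring on the carbonyl carbon, whereas this one shows that a change of a single group on an aromatic carbon, para to a large group, can by itself take the compound from a measured value to the edge of the assay. The full size of this loss cannot be read, because compound 4 gives a limit and not a number: the limit of > 100000 nM in this assay, at which 2 of the 4 values shown sit.

Going by these compounds, only fluoro and carboxy have been compared at this place, so it remains open whether the loss belongs to carboxy in particular or would follow many other replacements of fluoro. A methyl ester in place of the carboxylic acid, an amine or a chlorine on this carbon would help to settle that, and a plain phenyl ring with only hydrogen here would show how much the fluoro of compound 2 contributes to its value.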